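Compound 4: a sulfanyl group replacing the piperazine of compound 1

The source may hold more compounds than are shown below. What is called first, only, known or untested is meant among the compounds shown, and "the series" means these compounds.

Compound 1 `CN1CCN(c2cc(C(F)(F)F)nc(SCc3ccc(C(F)(F)F)cc3)n2)CC1`: 30200 nM
Compound 2 `FC(F)(F)c1ccc(CSc2nc(N3CCN(c4ncccn4)CC3)cc(C(F)(F)F)n2)cc1`: > 50000 nM (a limit)
Compound 3 `FC(F)(F)c1ccc(CSc2nc(Sc3ncccn3)cc(C(F)(F)F)n2)cc1`: > 50000 nM (a limit)

Within the data shown here, in a functional assay on MCF7 cells (Homo sapiens) for inhibition, read by MTT assay, with a stated time of 72 h (a higher number here means a weaker inhibitor, a lower number a stronger inhibitor), compound 1 carries the only actual number, and the rest of the series sits at the limit of > 50000 nM in this assay, at which 2 of the 3 values shown sit. Compound 4 `FC(F)(F)c1ccc(CSc2nc(Sc3nncs3)cc(C(F)(F)F)n2)cc1` is still unmeasured. The change is (1,3,4-thiadiazol-2-yl)sulfanyl in place of 4-methylpiperazin-1-yl on an aromatic carbon. The nearest guide is the other sulfanyl replacement, an at least 1.6-fold higher number from compound 1 to compound 3 (0.21 log units; that floor lies within the scatter). The change on the piperazine itself bears on it less directly, an at least 1.6-fold higher number from compound 1 to compound 2 (0.21 log units; that floor lies within the scatter). Both steps are floors only, so a higher number is expected but not shown. The expected step is a 1.5-fold higher number from compound 1 to compound 4 (0.17 log units; within the scatter). For compound 4 the estimated value is 45000 nM, with an expected range of 20000 nM to 90000 nM.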

Compound 4, half-maximal inhibitory concentration: 8810 nM
For compound 4 the middle estimate is 5.1-fold (0.71 log units) above the measured one, and the stated range ends above it.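

In this assay, the position opposite the ring nitrogen can give a lower number than the 4-methylpiperazin-1-yl group does: a 3.4-fold lower number from compound 1 to compound 4 (0.54 log units; beyond the scatter). The sulfur link alone does not decide this, since with that link held, the ring on it matters, as 1,3,4-thiadiazol-2-yl in place of pyrimidin-2-yl gives an at least 5.6-fold lower number from compound 3 to compound 4 (0.75 log units; beyond the scatter). Compound 3 stands at a limit of the assay and not at a number, as does compound 2: the limit of > 50000 nM in this assay, at which 2 of the 4 values shown sit.

Still open, from the compounds shown here alone, is whether a 1,3,4-oxadiazol-2-yl or phenyl ring on the sulfur keeps this step. Also open, going by these compounds, is whether an amine linking the 1,3,4-thiadiazol-2-yl ring in place of the sulfur does.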